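Swapping the phenyl group on an amide-type nitrogen

The source may hold more compounds than are shown below. What is called first, only, known or untested is meant among the compounds shown, and "the series" means these compounds.

In an ADME assay on MT4 cells (Homo sapiens) for cytotoxicity, read by MTT assay (a higher number here means that more compound is tolerated, a lower number that less compound is tolerated), compound 1 `COC(=O)c1ccc(NC(=O)CSc2nncnc2-c2cccc3ccccc23)c(Br)c1` gives 173000 nM, compound 3 `CC(=O)c1ccc(NC(=O)CSc2nncnc2-c2cccc3ccccc23)c(Br)c1` gives 133000 nM, and compound 2 `O=C(CSc1nncnc1-c1ccccc1Cl)Nc1ccc(Cl)cc1Cl` gives 51000 nM. Compound 3 cannot be told apart from compound 1 within the scatter, while compound 2 shows a lower number, a gap beyond the scatter. Compound 4 `Cc1ccc(NC(=O)CSc2nncnc2-c2cccc3ccccc23)c([N+](=O)[O-])c1` carries 4-methyl-2-nitrophenyl in place of 4-acetyl-2-bromophenyl on an amide-type nitrogen. Among the measured compounds shown here, the one measured step that bears on this, a 1.3-fold lower number from compound 1 to compound 3 (0.11 log units; within the scatter), put methyl in place of methoxy on a carbonyl carbon. For the measured compounds named here, no measured step covers the nitro group, so this guide is weak. The expected step is a 1.2-fold lower number from compound 3 to compound 4 (0.08 log units; within the scatter), with nothing beyond the scatter foreseen. Compound 4 is estimated at 110000 nM, with an expected range from 45000 nM to 220000 nM.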

Compound 4, half-maximal cytotoxic concentration: 147000 nM
Beside the measured number, compound 4's estimate is 1.3-fold (0.13 log units) below it, and the stated range covers the measured number.
By their numbers in this assay, from the lowest: compound 2; then compounds 3, 4 and 1 (each within the scatter of the next).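

Putting 4-methyl-2-nitrophenyl in place of 4-acetyl-2-bromophenyl on the amide-type nitrogen gives a 1.1-fold higher number from compound 3 to compound 4 (0.04 log units; within the scatter) in this assay. The earlier step altered only the group on a carbonyl carbon, whereas this one replaces the whole phenyl group, and the number still stays within the scatter. No evidence is available to explain this result. Going by these compounds, it remains open whether a phenyl group carrying an amine or a carboxylic acid at this position would also stay within the scatter. Whether such swaps behave alike on the core of compound 2 is also unknown.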